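Exposure in rat after an amine swap on the benzylic carbon

A few compounds are considered here, and "the series" means these few. Any claim that something is new, unique, unknown or untested is made for them only; others in the source may bear on it.

Two members of the series have been taken through an ADME assay on the whole organism for pharmacokinetics, with Rattus norvegicus as the target, with a stated time of 6 h, at a dose of 10 mg/kg by the oral route; on this read-out higher numbers stand for higher exposure at the dose given and lower numbers for lower exposure. Compound 1 `COc1cccc(Cc2cc(Nc3nc(C)cn4c(-c5cn[nH]c5)cnc34)sn2)n1` gives 2300 ng.h/mL in this assay. Compound 2 `Cc1cn2c(-c3cn[nH]c3)cnc2c(Nc2cc(C(c3ccccn3)N3CCCC3)ns2)n1` gives 9.15 ng.h/mL in this assay, the lower of the two numbers, and its gap to compound 1 lies well beyond the scatter of repeated runs. Among the measured compounds shown here, no pair of measured compounds differs in only one place, so no single-point step can be read from these two alone.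

Compound 3 `Cc1cn2c(-c3cn[nH]c3)cnc2c(Nc2cc(C(NC(C)(C)C)c3ccccn3)ns2)n1` has not yet been run. It differs from compound 2 by the change ((tert-butyl)amino in place of pyrrolidin-1-yl on a saturated chain carbon bound to two aromatic carbons), that is (tert-butyl)amino in place of pyrrolidin-1-yl on a saturated chain carbon bound to two aromatic carbons. Nothing measured in the series speaks directly to this exchange, so the expectation rests on compound 2 alone as the starting point. The expected step of a 2.2-fold higher number from compound 2 to compound 3 (0.34 log units; beyond the scatter) is taken as a modest rise, not far beyond the scatter, with the direction itself uncertain. Compound 3 is estimated at 20 ng.h/mL in this assay, within a range of 3 ng.h/mL to 150 ng.h/mL.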

Compound 3, area under the concentration-time curve: 735 ng.h/mL
The estimate for compound 3 lay 37-fold (1.57 log units) below the measured number; the whole stated range lies below it.
By their numbers in this assay, from the lowest: compound 2; then compound 3; then compound 1.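

Putting (tert-butyl)amino in place of pyrrolidin-1-yl on a saturated chain carbon bound to two aromatic carbons gives an 80-fold higher number from compound 2 to compound 3 (1.90 log units; beyond the scatter) in this assay. Among the compounds shown here, this is the first single-point step, and it shows that the read-out responds strongly to the choice of amine at this place, even though the two groups carry the same count of heavy atoms and differ only in that pyrrolidin-1-yl has a ring and (tert-butyl)amino has a hydrogen-bond donor. No supporting measurement bears on the step, so the pair cannot assign it to either difference.

Open, on these data alone, is whether a cyclic group that keeps the hydrogen-bond donor, such as cyclopentylamino, or an open-chain group without it, such as diethylamino, would follow compound 3 or compound 2, which would separate the ring from the donor. Also open, as far as these compounds go, is whether a smaller amine on the same carbon, such as isopropylamino, would stay close to compound 3 or whether the full tert-butyl group is needed.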